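Pyridin-3-yl to Methylthiazolyl on the Cyclopropane Ring

The compounds below may be only part of what the source reports. "The series", "measured", "known", "first", "only" and "open" are said of these compounds alone.

Compound 1, `CC[C@H](C)[C@H](N)CN(C(=O)[C@@H]1C[C@H]1C1CCCCC1)c1ccc(-c2ccccc2)cc1`, in a functional assay for agonist activity at G protein-coupled receptor 88 (Homo sapiens), read by HTRF and cAMP accumulation (on this read-out higher numbers stand for an effect only at larger amounts of compound and lower numbers for an effect already at smaller amounts), gives only a limit of the assay, > 25000 nM.
Compound 2, `CC[C@H](C)[C@H](N)CN(C(=O)[C@@H]1C[C@H]1c1cccnc1)c1ccc(-c2ccccc2)cc1`, in this assay gives 1500 nM.

Compound 2 thus holds the only true number shown; the value of compound 1 is a limit and no number. Among the compounds with values here, the single measured step is an at least 16-fold lower number from compound 1 to compound 2 (1.22 log units; beyond the scatter), with compound 1 sitting at the limit of > 25000 nM in this assay, at which 1 of the 2 values shown sits. Compound 3, `CC[C@H](C)[C@H](N)CN(C(=O)[C@@H]1C[C@H]1c1ncc(C)s1)c1ccc(-c2ccccc2)cc1`, differs from compound 2 in one place: 5-methyl-1,3-thiazol-2-yl in place of pyridin-3-yl on a saturated ring carbon. That measured step exchanged cyclohexyl for a ring with a hetero atom, so it bears only loosely on exchanging one such ring for another; it shows that pyridin-3-yl on that ring carbon works, not how a different ring compares. No step beyond the scatter is therefore expected in this assay. Compound 3 is estimated at 1500 nM, within 500 nM to 5000 nM. The expected step is no change at the digits printed from compound 2 to compound 3 (within the scatter).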

Compound 3, half-maximal effective concentration: 1300 nM
The estimate for compound 3 lay 1.2-fold (0.06 log units) above the measured number; the range from low to high includes it.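

On this saturated ring carbon, a five-membered aromatic ring and a six-membered one cannot be told apart in this assay: the result is a 1.2-fold lower number from compound 2 to compound 3 (0.06 log units; within the scatter). Pyridin-3-yl is therefore not the only group that works here, and a second aromatic ring also stands well clear of cyclohexyl, with an at least 19-fold lower number from compound 1 to compound 3 (1.28 log units; beyond the scatter). Compound 1 holds a limit and no number, so the exact size of that step stays unknown: the limit of > 25000 nM in this assay, at which 1 of the 3 values shown sits.

Open, from the compounds shown here alone, is how a plain phenyl group would compare on this carbon, which would show whether a hetero atom in the ring matters at all. Equally open, going by these compounds, are what the methyl group on the thiazole ring contributes and how an amine or a carboxylic acid on that ring would read.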